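The compounds below may be only part of what the source reports. "The series", "measured", "known", "first", "only" and "open" are said of these compounds alone.

Among the measured compounds shown here, compound 3 `O=c1cc(CCl)c2ccc(OCc3cccc(Cl)c3)cc2o1` gives 43.7 nM in an assay on isolated protein (strain Sprague-Dawley) for inhibition of Amine oxidase [flavin-containing] B (Rattus norvegicus), read by spectrophotometry, with a stated time of 5 min (on this read-out lower numbers stand for stronger inhibition and higher numbers for weaker inhibition), the lowest of the three numbers measured so far. Compound 1 `CC(C)Oc1cc(=O)oc2cc(OCc3cccc(Cl)c3)ccc12` gives 24500 nM and compound 2 `O=C(COc1cc(=O)oc2cc(OCc3cccc(Cl)c3)ccc12)N1CCCCC1` gives 38900 nM; the gaps to compound 3 are a 560-fold lower number from compound 1 to compound 3 (2.75 log units; beyond the scatter) and an 890-fold lower number from compound 2 to compound 3 (2.95 log units; beyond the scatter), both large, whereas a 1.6-fold higher number from compound 1 to compound 2 (0.20 log units; within the scatter). Compound 4 `O=c1cc(CO)c2ccc(OCc3cccc(Cl)c3)cc2o1` differs from compound 3 by hydroxy in place of chloro on a saturated chain carbon bound to an aromatic carbon. For the measured compounds named here, no measured step covers this exchange: the two large steps concern what stands on the aromatic carbon, not what stands on the chain carbon, so they give no direct guide. Going by the values given here, since the chloromethyl of compound 3 is the only group here paired with a low number, compound 4 is expected to give a higher number, an 18-fold higher number from compound 3 to compound 4 (1.26 log units; beyond the scatter), with wide uncertainty. Compound 4 is estimated at 800 nM, range 120 nM to 6000 nM.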

Compound 4, half-maximal inhibitory concentration: 5.25 nM
For compound 4 the middle estimate is 150-fold (2.18 log units) above the measured one; the whole stated range lies above it.
By their numbers in this assay, from the lowest: compound 4; then compound 3; then compounds 1 and 2 (each within the scatter of the next).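

On the saturated chain carbon bound to an aromatic carbon, chloro is not needed for a low number in this assay, since hydroxy in its place gives an 8.3-fold lower number from compound 3 to compound 4 (0.92 log units; beyond the scatter) and the number falls further. Hydroxymethyl also keeps the large gaps to the earlier compounds, with a 4700-fold lower number from compound 1 to compound 4 (3.67 log units; beyond the scatter) and a 7400-fold lower number from compound 2 to compound 4 (3.87 log units; beyond the scatter) on the same aromatic carbon. No evidence at hand bears on this chloro to hydroxy exchange. Still open, from the compounds shown here alone, is whether an amine, a methyl ether or a carboxylic acid in place of the hydroxy would keep the number this low.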